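This account rests on a few compounds, and the source may have more. Where it says the series, first, only, none or still open, it means among the compounds named here.

Of the compounds shown here, three built on one shared core have been tested in an ADME assay on the whole organism for cytotoxicity, with Artemia salina as the target, with a stated time of 24 h; a lower number here means that less compound is needed, a higher number that more compound is needed for the effect. Compound 1 `Cc1ccc(/C=C/C(=O)c2ccccc2NC(=O)NS(=O)(=O)c2ccc(C)cc2)cc1` gives 15.3 ug/mL, compound 2 `Cc1ccc(S(=O)(=O)NC(=O)Nc2ccccc2C(=O)/C=C/c2ccc(N(C)C)cc2)cc1` gives 38.1 ug/mL, and compound 3 `Cc1ccc(S(=O)(=O)NC(=O)Nc2ccccc2C(=O)/C=C/c2ccccc2Cl)cc1` gives 12.8 ug/mL. The step of a 1.2-fold lower number from compound 1 to compound 3 (0.08 log units; within the scatter) stays within the scatter, whereas the step of a 3.0-fold lower number from compound 2 to compound 3 (0.47 log units; beyond the scatter) lies beyond it, so compound 3 stands apart only from compound 2. Compound 4 `C=CCOc1ccc(/C=C/C(=O)c2ccccc2NC(=O)NS(=O)(=O)c2ccc(C)cc2)cc1` differs from compound 3 in one place: 4-(allyloxy)phenyl in place of 2-chlorophenyl on a double-bonded chain carbon bound to a double-bonded chain carbon. Both measured steps that end at compound 3 swap a ring of this kind for the 2-chlorophenyl, one with no change and one with a modest lowering. Going the other way, a modest rise in this assay is therefore expected, a 1.6-fold higher number from compound 3 to compound 4 (0.19 log units; within the scatter). The estimate for compound 4 is 20 ug/mL, with a range from 10 ug/mL to 40 ug/mL.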

Compound 4, concentration for half-maximal effect: 6.11 ug/mL
For compound 4 the middle estimate is 3.3-fold (0.51 log units) above the measured one, outside the stated range (below it).
By their numbers in this assay, from the lowest: compound 4; then compounds 3 and 1 (each within the scatter of the next); then compound 2.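

Going by these compounds alone, the ring at this position, on a double-bonded chain carbon bound to a double-bonded chain carbon, can lower the number further than the earlier compounds showed: in this assay the 4-(allyloxy)phenyl group gives a 2.1-fold lower number from compound 3 to compound 4 (0.32 log units; beyond the scatter) and also a 2.5-fold lower number from compound 1 to compound 4 (0.40 log units; beyond the scatter) as well as a 6.2-fold lower number from compound 2 to compound 4 (0.79 log units; beyond the scatter). Compound 4 therefore has the lowest number of the four, with every step to it beyond the scatter. Nothing measured here gives a reason for this drop. Still open, on these data alone, is whether the oxygen or the allyl end matters, which methoxy or propoxy on the same aromatic carbon could separate.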